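The source may hold more compounds than are shown below. What is called first, only, known or untested is meant among the compounds shown, and "the series" means these compounds.

Compound 1 `CNC(=O)c1cc(C(=O)N[C@H]2CC[C@H](O)CC2)n([C@@H](C)c2ccc(Cl)cc2)n1` is the point of departure. In an ADME assay for permeability (on this read-out higher numbers stand for higher permeability and lower numbers for lower permeability), compound 1 gives 180 nm/s. Among the measured compounds shown here, its closest neighbour among the measured compounds is compound 2 `CNC(=O)c1cc(C(=O)N[C@H]2CC[C@H](O)CC2)c([C@@H](C)c2ccc(Cl)cc2)o1`, which carries the same side groups on a different core and in this assay gives 150 nm/s, a number that sits within the usual scatter of the one for compound 1. Compound 3 `CNC(=O)c1cc(C(=O)NC2CC2)n(Cc2ccccc2)n1` is reported in this assay only as a limit, > 80 nm/s, and so offers no number to set beside the other two (the limit of > 80 nm/s in this assay, at which 1 of the 3 values shown sits).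

Compound 4 `CNC(=O)c1cc(C(=O)N[C@H]2CC[C@H](O)CC2)n([C@@H](C)c2ccc(C(F)(F)F)cc2)n1` has not yet been measured. It differs from compound 1 in one place: trifluoromethyl in place of chloro on an aromatic carbon. For the measured compounds named here, no pair of measured compounds shows this same change, so there is no measured step to lean on. The account expects the step from compound 1 to compound 4 in this assay to be a 1.1-fold higher number from compound 1 to compound 4 (0.05 log units; within the scatter), which stays within the scatter. On that basis compound 4 is estimated to give 200 nm/s, with a range from 100 nm/s to 400 nm/s.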

Compound 4, apparent permeability: 270 nm/s
Beside the measured number, compound 4's estimate is 1.4-fold (0.13 log units) below it, within the range that was stated.
By their numbers in this assay, from the lowest: compounds 2, 1 and 4 (each within the scatter of the next).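

Compounds 1 and 2 both carry chloro at this place, so only now is there a number for a different group on this aromatic carbon, para to a large group. In this assay the exchange of chloro for trifluoromethyl reads as a 1.5-fold higher number from compound 1 to compound 4 (0.18 log units; within the scatter) and so does not separate the two compounds on this read-out, even though the entering group is the larger by its count of heavy atoms. Nothing measured among the compounds shown speaks to what lies behind this step.

Going by these compounds, whether a nitrile, a methoxy group or an amine at this same place would also stay level with chloro remains open. So does whether trifluoromethyl in place of chloro would give a step of similar size on the core of compound 2.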